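Cyclobutylcarbonyl on the ring amine of a TLR8 agonist scaffold

The source may hold more compounds than are shown below. What is called first, only, known or untested is meant among the compounds shown, and "the series" means these compounds.

Measured compounds:
compound 1 `CCCCNc1nc(N)nc2c1CNCC2`: 7.2 uM
compound 2 `CCCCNc1nc(N)nc2c1CN(Cc1ccc(OC(F)(F)F)cc1)CC2`: 0.24 uM
compound 3 `CCCCNc1nc(N)nc2c1CN(Cc1c[nH]c3ccccc13)CC2`: 0.22 uM

In an assay on HEK293 cells for agonist activity at Toll-like receptor 8 (Homo sapiens), read by a luciferase reporter, with a stated time of 6 h (a lower number here means that less compound is needed, a higher number that more compound is needed for the effect), compound 1 gives 7.2 uM, the highest of the three numbers. Compound 2, which carries a substituent on the ring nitrogen of the shared core, gives 0.24 uM, and compound 3 gives 0.22 uM; both lie well beyond the scatter from compound 1, and the two of them lie within the scatter of each other.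

Compound 4 `CCCCNc1nc(N)nc2c1CN(C(=O)C1CCC1)CC2` follows the same line of substitution at that nitrogen, but with a different kind of group: cyclobutylcarbonyl in place of hydrogen on an amine nitrogen in a ring. Among the compounds with values here, nothing among the measured compounds shows what a carbonyl-linked group does there, only that substituents of another sort lower the number considerably. The step from compound 1 to compound 4 is therefore expected to go downward, by less than the benzylic examples show, with a 4.8-fold lower number from compound 1 to compound 4 (0.68 log units; beyond the scatter) as the estimated size. Compound 4 is expected to give 1.5 uM, within a range from 0.4 uM to 6 uM.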

Compound 4, minimum effective concentration: 0.4 uM
The estimate for compound 4 lay 3.8-fold (0.57 log units) above the measured number; low and high end bracket the measured number.
By their numbers in this assay, from the lowest: compounds 3, 2 and 4 (each within the scatter of the next); then compound 1.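

In this assay, the ring amine nitrogen of the shared core accepts a carbonyl-linked group as well as the groups joined through a methylene in compound 2 and compound 3: cyclobutylcarbonyl in place of hydrogen gives an 18-fold lower number from compound 1 to compound 4 (1.26 log units; beyond the scatter). Within the data shown here, a much smaller group than the aromatic substituents of the earlier compounds is thus enough here, and compound 4 stands within the scatter of compound 2, so this step is not confined to groups carrying an aromatic ring. Nothing shown here accounts for why this change lowers the number.

The compounds shown leave open how an acetyl, a cyclohexylcarbonyl or a benzoyl group on this nitrogen would compare with cyclobutylcarbonyl. They also leave open how a cyclobutylmethyl group, which has no carbonyl, would compare with compound 4, so the part played by the carbonyl itself cannot be read.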